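This account rests on a few compounds, and the source may have more. Where it says the series, first, only, none or still open, it means among the compounds named here.

Three compounds have so far been measured in a functional assay on DU-145 cells (Homo sapiens) for inhibition, read by trypan blue exclusion, with a stated time of 96 h; a higher number here means a weaker inhibitor of growth, a lower number a stronger inhibitor of growth:

compound 1, `O=C(/C(=C\c1ccc(Br)c([N+](=O)[O-])c1)Sc1ccc(Br)cc1)c1ccc(Br)cc1`, 1000 nM
compound 2, `COc1ccc(/C=C(/SCc2ccc(F)cc2)C(=O)c2ccc(Cl)cc2)c(OC)c1OC`, 10000 nM
compound 3, `COc1ccc(/C=C(/Sc2ccccc2Cl)C(=O)c2ccc(Cl)cc2)c(OC)c1OC`, 10000 nM

Compound 3 stands level with compound 2 at the digits reported, the two of them together giving the highest numbers of the three; compound 1 gives a lower number, and that gap lies beyond the scatter. Among the measured compounds shown here, the one single-point step among them, no change at the digits printed from compound 2 to compound 3 (within the scatter), went with a 2-chlorophenyl in place of a 4-fluorobenzyl on a sulfur and left the read-out unchanged within the scatter.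

Compound 4, `COc1ccc(/C=C(\C(=O)c2ccc(Cl)cc2)S(=O)(=O)Cc2ccc(Cl)cc2)c(OC)c1OC`, differs from compound 3 in one place: (4-chlorobenzyl)sulfonyl in place of (2-chlorophenyl)sulfanyl on a double-bonded chain carbon bound to a carbonyl carbon and a double-bonded chain carbon. For the measured compounds named here, no measured pair shows a sulfonyl entering for a sulfanyl, so nothing bears on that part of the change directly; the only step that touches the same sulfur, no change at the digits printed from compound 2 to compound 3 (within the scatter), was flat. On that basis he expects no step beyond the scatter, no change at the digits printed from compound 3 to compound 4 (within the scatter), in this assay. His estimate for compound 4 is 10000 nM, within a range from 3000 nM to 30000 nM.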

Compound 4, concentration for 50% growth inhibition: 10000 nM
Compound 4: middle estimate and measured number agree at the digits printed; low and high end bracket the measured number.
By their numbers in this assay, from the lowest: compound 1; then compounds 2, 3 and 4 (each within the scatter of the next).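

In this assay the exchange of (2-chlorophenyl)sulfanyl for (4-chlorobenzyl)sulfonyl gave no change at the digits printed from compound 3 to compound 4 (within the scatter) and so showed that this place can carry a sulfonyl, not only a sulfanyl, with the read-out unchanged within the scatter. The exchange of (4-fluorobenzyl)sulfanyl for (4-chlorobenzyl)sulfonyl gave no change at the digits printed from compound 2 to compound 4 (within the scatter) and so extended the flat picture to all three groups seen on this carbon of the shared core. No measurement at hand bears on this result.

Steps to compound 1 cannot be read, since it differs from the others in more than one place. Going by these compounds, it remains open whether an amine, a carboxylic acid or a longer alkyl chain on this carbon would move the number beyond the scatter.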